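This account rests on a few compounds, and the source may have more. Where it says the series, first, only, none or still open, it means among the compounds named here.

Compound 1 `Oc1c(C(Nc2ccccn2)c2ccccc2Cl)ccc2cccnc12` and compound 2 `Oc1c(C(c2ccc(F)cc2)N2CCCCC2)ccc2cnccc12` are the two measured compounds. In an assay for inhibition of protein disulfide-isomerase (Homo sapiens), with a stated time of 1 h (a higher number here means a weaker inhibitor, a lower number a stronger inhibitor), compound 1 gives 500 nM, and in this assay compound 2 gives 610 nM; the two numbers lie within the scatter of each other, so neither stands apart. Compound 3 `Cc1cc(C)c(C(Nc2ccccn2)c2ccc3cccnc3c2O)c(C)c1` has not been measured. It differs from compound 1 in one place: 2,4,6-trimethylphenyl in place of 2-chlorophenyl on a saturated chain carbon bound to an aromatic carbon and a nitrogen on an aromatic ring. For the measured compounds named here, no measured pair shows what such a change does, so the step is expected to stay within the scatter, with no clear direction, giving for compound 3 an estimated 700 nM (from 250 nM to 2000 nM), which means an expected step of a 1.4-fold higher number from compound 1 to compound 3 (0.15 log units; within the scatter).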

Compound 3, half-maximal inhibitory concentration: 190 nM
The estimate for compound 3 lay 3.7-fold (0.57 log units) above the measured number; the whole stated range lies above it.
By their numbers in this assay, from the lowest: compound 3; then compounds 1 and 2 (each within the scatter of the next).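

Replacing 2-chlorophenyl with 2,4,6-trimethylphenyl on this saturated chain carbon lowers the number in this assay (a 2.6-fold lower number from compound 1 to compound 3 (0.42 log units; beyond the scatter)). So this position accepts a ring carrying 9 heavy atoms rather than 7, and chlorine on the ring is not needed for a number this low. Nothing available here gives a reason for the step.

This single change leaves open whether the methyl groups or the loss of chlorine accounts for the step. Also open, on these data alone, is how an unsubstituted phenyl, or a ring bearing a carboxylic acid or an amine, would behave here.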